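The compounds below may be only part of what the source reports. "The series", "measured", "known", "first", "only" and "open" are said of these compounds alone.

Three compounds share one core and differ only in the group attached to one of the two amide carbonyls. Compound 1 `O=C(COc1ccc2c(=O)ccoc2c1)Nc1cccc(NC(=O)c2ccc(Br)cc2)c1` gives 303 nM in an assay on isolated protein for inhibition of Rho-associated protein kinase 1 (Homo sapiens), read by scintillation counting, radiometric assay and 33P incorporation, with a stated time of 40 min, in the presence of a further agent that is not named here; on this read-out higher numbers stand for weaker inhibition and lower numbers for stronger inhibition. Compound 2 `COc1ccc(C(=O)Nc2cccc(NC(=O)COc3ccc4c(=O)ccoc4c3)c2)cc1` gives 18 nM, and compound 3 `COC(=O)c1ccc(C(=O)Nc2cccc(NC(=O)COc3ccc4c(=O)ccoc4c3)c2)cc1` gives 72 nM. Among these three numbers compound 3 stands second highest, between the other two: a 4.0-fold higher number from compound 2 to compound 3 (0.60 log units; beyond the scatter), and a 4.2-fold lower number from compound 1 to compound 3 (0.62 log units; beyond the scatter).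

Compound 4 `Cc1cc(C(=O)Nc2cccc(NC(=O)COc3ccc4c(=O)ccoc4c3)c2)ccc1C(F)(F)F` is not yet measured. It carries a group of 11 heavy atoms (8 carbon, 3 fluorine; one six-membered aromatic ring of carbon only) in place of a group of 10 heavy atoms (8 carbon, 2 oxygen; one six-membered aromatic ring of carbon only), on a carbonyl carbon. Going by the values given here, no measured pair makes this exact swap; the nearest guidance comes from the three changes on the same aromatic carbon, which gave a 17-fold lower number from compound 1 to compound 2 (1.23 log units; beyond the scatter), a 4.2-fold lower number from compound 1 to compound 3 (0.62 log units; beyond the scatter) and a 4.0-fold higher number from compound 2 to compound 3 (0.60 log units; beyond the scatter). The entering group, like the bromo of compound 1, brings no hydrogen-bond acceptors, so a move back toward the higher number of compound 1 seems plausible, but this rests on one analogy only. A step of a 2.8-fold higher number from compound 3 to compound 4 (0.44 log units; beyond the scatter) is therefore expected. Compound 4 is expected to give about 200 nM, with a range from 50 nM to 800 nM.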

Compound 4, half-maximal inhibitory concentration: 460 nM
Compound 4: the middle estimate sits 2.3-fold (0.36 log units) below what was measured; measured number inside the range.
By their numbers in this assay, from the lowest: compound 2; then compound 3; then compounds 1 and 4 (each within the scatter of the next).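

Compound 4 shows that this place on the carbonyl carbon tolerates large swings even among groups built on one aromatic ring: there is a 6.4-fold higher number from compound 3 to compound 4 (0.81 log units; beyond the scatter), and a 26-fold higher number from compound 2 to compound 4 (1.41 log units; beyond the scatter). Set against the bromo-bearing group there is a 1.5-fold higher number from compound 1 to compound 4 (0.18 log units; within the scatter), so a second group without hydrogen-bond acceptors lands level with compound 1, while the two groups that carry acceptors, in compound 2 and compound 3, give the lower numbers. Across these four compounds that is only a correlation, and no measurement here explains it.

The entering group carries both a methyl and a trifluoromethyl, so their separate contributions cannot be told apart. From the compounds shown here alone, how an amine or a carboxylic acid on the same ring would read out also remains open.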